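Adding a nitro group to compound 2

A few compounds are considered here, and "the series" means these few. Any claim that something is new, unique, unknown or untested is made for them only; others in the source may bear on it.

Compound 1 `COc1cc(-c2ccnc3cc(-c4ccc5c(ccn5C)c4)nn23)cc(OC)c1OC` gives 48 nM
Compound 2 `COc1ccc(-c2cc3nccc(-c4cc(OC)c(OC)c(OC)c4)n3n2)cc1` gives 1410 nM
Compound 3 `COc1cc(-c2ccnc3cc(-c4ccc(-c5cnn(C)c5)cc4)nn23)cc(OC)c1OC` gives 1240 nM

All three numbers come from a functional assay on B16-F0 cells (Mus musculus) for inhibition, read by CCK-8 assay, with a stated time of 48 h (a lower number here means a stronger inhibitor, a higher number a weaker inhibitor), and a lower number marks a stronger inhibitor. Compound 2 sits at the weak end of this small set. It cannot be told apart from compound 3, and only compound 1 stands clearly away from it.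

Compound 4 `COc1ccc(-c2cc3nccc(-c4cc(OC)c(OC)c(OC)c4)n3n2)cc1[N+](=O)[O-]` is compound 2 with one change: nitro in place of hydrogen on an aromatic carbon. The new group lands ortho to a methoxy group, on the same aryl group that both measured steps alter. One of those steps is large, showing a 29-fold higher number from compound 1 to compound 2 (1.47 log units; beyond the scatter) but it swaps the whole aryl group. The other is closer in kind, a swap on that same ring showing a 1.1-fold lower number from compound 2 to compound 3 (0.06 log units; within the scatter) and so no real change. Neither step adds a nitro, so the data give no direct measure of this change and no direction for it.

In this assay no step beyond the scatter is therefore expected, only a wide uncertainty. The expected step is a 1.1-fold higher number from compound 2 to compound 4 (0.05 log units; within the scatter) and it could still turn out larger either way. For compound 4 the estimated value is 1600 nM with an expected range from 400 nM to 6000 nM (an estimate, not a measurement).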

Compound 4, half-maximal inhibitory concentration: > 10000 nM
Compound 4 gave a limit, no number; the forecaster's own chance of this, stated with the estimate: 10%; middle value at least 6.2-fold (0.79 log units) from the limit.
By their numbers in this assay, from the lowest: compound 1; then compounds 3 and 2 (each within the scatter of the next). At a limit, above all of these: compound 4.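

For the compounds shown here, earlier, the only change on this aryl group that could be compared with a small swap was the replacement of methoxy by 1-methyl-1H-pyrazol-4-yl, and it gave a 1.1-fold lower number from compound 2 to compound 3 (0.06 log units; within the scatter), which suggested little sensitivity to a modest change on this ring. The new position, ortho to a methoxy group, behaves differently in this assay: adding nitro, just 3 heavy atoms in place of a hydrogen atom, gives an at least 7.0-fold higher number from compound 2 to compound 4 (0.85 log units; beyond the scatter), so a small addition on this ring can cost a clear loss of inhibition. Compound 4 gives a limit and not a number, so this step has a lower bound but no known size: the limit of > 10000 nM in this assay, at which 1 of the 4 values shown sits.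

An amine or a methyl group at this same place would show whether the loss follows nitro in particular or any group put there. Also open, from the compounds shown here alone, is whether nitro would have a similar effect on the aryl group of compound 3, where the ring carries 1-methyl-1H-pyrazol-4-yl in place of methoxy.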